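The source may report more compounds than this note shows. Statements on the series, on what has been measured and on what is new or still open speak of the compounds shown alone.

Working notes on the series. Within the data shown here, in a functional assay on the whole organism with Rattus norvegicus as the target (on this read-out lower numbers stand for an effect already at smaller amounts and higher numbers for an effect only at larger amounts of compound), compound 1 `C/N=C(\NC#N)NCCCCn1nc(-c2ccccc2)ccc1=O` gives 38.5 mg/kg and stands second highest of the three numbers so far. Compound 2 `NC(=O)SCCCCCN1NC=CC=C1c1ccccc1` gives 18.3 mg/kg in this assay, a lower number than compound 1 by more than the scatter. Compound 3 `CN(C)/C(=N/CCCCCCn1nc(-c2ccccc2)ccc1=O)NC#N` gives 92.5 mg/kg in this assay, a higher number than compound 1 by more than the scatter. Compound 4 `C=CCNC(=S)NCCCCn1nc(-c2ccccc2)ccc1=O` is not yet measured; it differs from compound 1 in this way: a group of 6 heavy atoms (4 carbon, 1 nitrogen, 1 sulfur; no ring) in place of a group of 6 heavy atoms (3 carbon, 3 nitrogen; no ring), on an amine nitrogen. Among the measured compounds shown here, no measured pair shows this change, so the size of the step is open; a step near or within the scatter is expected, with no clear direction. Compound 4 is expected to give about 30 mg/kg in this assay, within 12 mg/kg to 75 mg/kg, which means an estimated step of a 1.3-fold lower number from compound 1 to compound 4 (0.11 log units; within the scatter).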

Compound 4, dose for half-maximal effect: 78.6 mg/kg
Estimate against measurement, compound 4: 2.6-fold (0.42 log units) below, outside the stated range (above it).
By their numbers in this assay, from the lowest: compound 2; then compound 1; then compounds 4 and 3 (each within the scatter of the next).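

In this assay, among these compounds, the first readable step at this amine nitrogen is a 2.0-fold higher number from compound 1 to compound 4 (0.31 log units; beyond the scatter) and lies beyond the scatter, though it is modest. With the chain and the core of compound 1 held fixed, a group of 6 heavy atoms (4 carbon, 1 nitrogen, 1 sulfur; no ring) in place of one of 6 heavy atoms (3 carbon, 3 nitrogen; no ring) is therefore not a neutral exchange here, despite the equal heavy-atom count. No measurement at hand accounts for this step. From the compounds shown here alone, whether a morpholine or a simple primary amine at this place would give a lower number remains open. So does whether the step carries over to a longer chain.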